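The compounds below may be only part of what the source reports. "The series", "measured", "known", "first", "only" and "open" are said of these compounds alone.

Compound 1 `O=C1c2c[n+]([O-])c3ccccc3c2C(=O)c2c1c1ccccc1n2CCCCn1ccnc1` and compound 2 `O=C1c2c[n+]([O-])c3ccccc3c2C(=O)c2c1c1ccccc1n2CCN1CCCC1` share the same core and differ only in the chain attached to the aromatic nitrogen. In a functional assay on MDA-MB-231 cells (Homo sapiens) for cytotoxicity, read by MTT assay, with a stated time of 72 h (a lower number here means a stronger inhibitor, a higher number a weaker inhibitor), compound 1 gives 210 nM, while compound 2 gives 630 nM. Within the data shown here, compound 1 thus holds the lower of the two numbers and is the stronger inhibitor of the pair; the only measured step, a 3.0-fold higher number from compound 1 to compound 2 (0.48 log units; beyond the scatter), runs upward. Compound 3 `O=C1c2c[n+]([O-])c3ccccc3c2C(=O)c2c1c1ccccc1n2CCCN1CCC(O)CC1` is not yet measured. It differs from compound 1 by 4-hydroxypiperidin-1-yl in place of (1H-imidazol-1-yl)methyl on a saturated chain carbon, three bonds along the chain from an aromatic nitrogen. Like the step to compound 2, which brought in pyrrolidin-1-yl, this change removes the five-membered aromatic ring with 2 hetero atoms in favour of a six-membered non-aromatic ring with 1 hetero atom, so that single measured step is the one that bears on it, and a modest rise of similar size is expected rather than no change. Compound 3 is therefore expected to give 500 nM in this assay, with a range from 220 nM to 1100 nM. That would be a step of a 2.4-fold higher number from compound 1 to compound 3 (0.38 log units; beyond the scatter), expected on the basis of the step to compound 2.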

Compound 3, half-maximal inhibitory concentration: 280 nM
Beside the measured number, compound 3's estimate is 1.8-fold (0.25 log units) above it, within the range that was stated.
By their numbers in this assay, from the lowest: compounds 1 and 3 (each within the scatter of the next); then compound 2.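

In this assay, the step of a 1.3-fold higher number from compound 1 to compound 3 (0.12 log units; within the scatter) shows that, at this place on the chain, the five-membered aromatic ring with 2 hetero atoms can give way to a six-membered non-aromatic ring with 1 hetero atom without a change beyond the scatter, so compound 2 alone had not shown what such a swap does in general. The step of a 2.3-fold lower number from compound 2 to compound 3 (0.35 log units; beyond the scatter) adds that the two non-aromatic end groups are not interchangeable here, although 2-(4-hydroxypiperidin-1-yl)ethyl on the one side and the shorter group ending in pyrrolidin-1-yl on the other differ in both ring and chain length, so the two influences cannot be separated. No measurement shown here accounts for these numbers.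

On these data alone, whether the hydroxyl group contributes remains open, and plain piperidin-1-yl on the same propyl chain would address that directly. Also open, as far as these compounds go, is how pyrrolidin-1-yl behaves on a propyl or butyl chain, and whether morpholin-4-yl or a carboxylic acid at the chain end would fit this place equally well.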